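The source may report more compounds than this note shows. Statements on the series, on what has been measured and on what is new or still open speak of the compounds shown alone.

Compound 1 `CC(C)C(c1ccc(-c2ccc3cccc(F)c3c2)[nH]c1=O)N1CCNC1=O` stands in the middle of a small set measured in an ADME assay on microsomes from liver (Homo sapiens) for metabolic stability (a lower number here means that the compound disappears faster, a higher number that the compound lasts longer), where compound 1 gives 1.03 h. For the measured compounds named here, compound 3 `CC(C)[C@@H](C[C@H]1CCNC1=O)c1ccc(-c2ccc3cccc(F)c3c2)[nH]c1=O` gives 0.693 h in this assay, a number that lies within the usual scatter of the one for compound 1, so the two cannot be told apart. Compound 2 `CCn1ncc2c(F)cc(-c3ccc(C(CC)(CC)c4nnc[nH]4)c(=O)[nH]3)cc21` gives 2.7 h in this assay, a number that stands beyond the scatter on the higher side of compound 1.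

Compound 4 `Cc1c[nH]c(C(c2ccc(-c3ccc4cccc(F)c4c3)[nH]c2=O)C(C)C)n1` has not yet been measured. It differs from compound 1 in one place: 4-methyl-1H-imidazol-2-yl in place of 2-oxoimidazolidin-1-yl on a saturated chain carbon bound to an aromatic carbon and a saturated chain carbon. The leaving group is a five-membered non-aromatic ring with 2 hetero atoms carrying 1 double bond outside aromatic rings; the entering group is a five-membered aromatic ring with 2 hetero atoms. Going by the values given here, no measured pair shows this exact change, so its size cannot be read from the set. In this assay a step of a 1.3-fold lower number from compound 1 to compound 4 (0.11 log units; within the scatter) is expected, one that stays within the usual scatter or leans slightly toward a shorter half-life. The estimated half-life of compound 4 in this assay is 0.8 h, with a likely range from 0.4 h to 1.6 h.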

Compound 4, half-life: 0.09 h
Compound 4: the middle estimate sits 8.9-fold (0.95 log units) above what was measured; the whole stated range lies above it.
By their numbers in this assay, from the lowest: compound 4; then compounds 3 and 1 (each within the scatter of the next); then compound 2.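

On the saturated chain carbon bound to an aromatic carbon and a saturated chain carbon, the choice of group matters greatly in this assay: 4-methyl-1H-imidazol-2-yl in place of 2-oxoimidazolidin-1-yl gives an 11-fold lower number from compound 1 to compound 4 (1.06 log units; beyond the scatter). The two groups match in heavy atoms, hydrogen-bond donors, hydrogen-bond acceptors and net charge, so these counts alone cannot forecast the size of this step. Nothing available here explains the drop in half-life.

From the compounds shown here alone, it remains open whether the drop follows the imidazole ring itself or its methyl group, a question that the plain 1H-imidazol-2-yl group at this carbon would address. Going by these compounds, how an open-chain urea would behave at the same carbon also remains unknown.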